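Extending the Alkene Chain of Compound 3

The source may report more compounds than this note shows. Statements on the series, on what has been measured and on what is new or still open speak of the compounds shown alone.

Three compounds share one core and differ only in the group attached to the amide carbonyl carbon. Compound 1 `C=CC(=O)Nc1cc2c(N3CCc4ccccc43)ncnc2cc1OC` gives 5940 nM in a functional assay on PC-3 cells (Homo sapiens) for antiproliferative activity, read by MTT assay, with a stated time of 72 h; a lower number here means a stronger inhibitor, a higher number a weaker inhibitor. Compound 2 `COc1cc2ncnc(N3CCc4ccccc43)c2cc1NC(=O)C=C(C)C` gives 7840 nM, and compound 3 `C/C=C/C(=O)Nc1cc2c(N3CCc4ccccc43)ncnc2cc1OC` gives 8120 nM. Compound 3 stands at the highest number of the three, yet each gap lies within the scatter: a 1.3-fold higher number from compound 1 to compound 2 (0.12 log units; within the scatter), a 1.4-fold higher number from compound 1 to compound 3 (0.14 log units; within the scatter) and a 1.0-fold higher number from compound 2 to compound 3 (0.02 log units; within the scatter). Compound 4 `CCC/C=C/C(=O)Nc1cc2c(N3CCc4ccccc43)ncnc2cc1OC` carries ethyl in place of hydrogen on a saturated chain carbon bound to a double-bonded chain carbon. The three measured changes on this same alkene chain all left this assay within the scatter, so the step to compound 4 is expected to be small as well, a 1.1-fold higher number from compound 3 to compound 4 (0.04 log units; within the scatter). Compound 4 is therefore estimated at 9000 nM, within a range from 4000 nM to 20000 nM.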

Compound 4, half-maximal inhibitory concentration: 4240 nM
For compound 4 the middle estimate is 2.1-fold (0.33 log units) above the measured one; the measured number falls inside the stated range.
By their numbers in this assay, from the lowest: compounds 4, 1, 2 and 3 (each within the scatter of the next).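

Adding ethyl in place of hydrogen on a saturated chain carbon bound to a double-bonded chain carbon, which turns prop-1-en-1-yl into pent-1-en-1-yl, gives a step that stays within the scatter in this assay (a 1.9-fold lower number from compound 3 to compound 4 (0.28 log units; within the scatter)). The same holds against the shorter groups (a 1.8-fold lower number from compound 2 to compound 4 (0.27 log units; within the scatter); a 1.4-fold lower number from compound 1 to compound 4 (0.15 log units; within the scatter)), so this position accepts a longer chain without a change that can be told from repeat measurements. Nothing shown gives a reason for this.

On these data alone, whether a longer chain than ethyl, or an amine, at this same place would give a step beyond the scatter remains open.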